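Ester Chain Length and Calcium Channel Antagonism

The compounds below may be only part of what the source reports. "The series", "measured", "known", "first", "only" and "open" are said of these compounds alone.

Compound 1, `CCOC(=O)C1=C(C)NC(C)=C(C(=O)OCC)C1c1cnc(SC)n1Nc1ccccc1`: 1.69 nM
Compound 2, `CSc1ncc(C2C(C(=O)OC(C)C)=C(C)NC(C)=C2C(=O)OC(C)C)n1Nc1ccccc1`: 2.16 nM
Compound 3, `COC(=O)C1=C(C)NC(C)=C(C(=O)OC(C)C)C1c1cnc(SC)n1Nc1ccccc1`: 6.35 nM

The three measured compounds share one core and differ only in their two ester groups. In an assay on isolated protein (strain albino) for antagonist activity at Voltage-dependent L-type calcium channel subunit alpha-1C (Cavia porcellus) (on this read-out lower numbers stand for stronger inhibition and higher numbers for weaker inhibition), compound 3 stands at the highest number of the three; compound 2 lies lower at 2.16 nM and compound 1 lower still at 1.69 nM. Compound 4, `CCOC(=O)C1=C(C)NC(C)=C(C(=O)OC(C)C)C1c1cnc(SC)n1Nc1ccccc1`, differs from compound 3 by methyl in place of hydrogen on a saturated chain carbon bound to an oxygen next to a carbonyl group. For the measured compounds named here, the one measured step that bears on this is a 2.9-fold higher number from compound 2 to compound 3 (0.47 log units; beyond the scatter), where a longer ester chain went with the lower number. Lengthening the remaining methyl ester in compound 3 is therefore expected to give a step of a 2.4-fold lower number from compound 3 to compound 4 (0.39 log units; beyond the scatter). Compound 4 is estimated at 2.6 nM, with a range from 1.2 nM to 5.5 nM.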

Compound 4, half-maximal inhibitory concentration: 3.22 nM
Compound 4: the middle estimate sits 1.2-fold (0.09 log units) below what was measured; the measured number falls inside the stated range.
By their numbers in this assay, from the lowest: compounds 1, 2, 4 and 3 (each within the scatter of the next, the first and the last beyond it).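

Read alone, methyl to ethyl on the saturated chain carbon bound to an oxygen next to a carbonyl group gives a 2.0-fold lower number from compound 3 to compound 4 (0.29 log units; within the scatter) in this assay. The ethyl and isopropyl esters are not separated here either, with a 1.5-fold higher number from compound 2 to compound 4 (0.17 log units; within the scatter) and a 1.9-fold higher number from compound 1 to compound 4 (0.28 log units; within the scatter). Among these compounds only the methyl-to-isopropyl step lies beyond the scatter, so a single added methyl does not clear it.

As far as these compounds go, a longer chain such as butyl, or a carboxylic acid in place of the ester, remains open. No evidence bears on the cause of these steps.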